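This account rests on a few compounds, and the source may have more. Where it says the series, first, only, none or still open, it means among the compounds named here.

Working notes on the series. In an assay on HEK293 cells for displacement of a labelled ligand from adenosine receptor A2b (Homo sapiens), read by scintillation counting, with a stated time of 30 min, tested at 10 uM (on this read-out lower numbers stand for less inhibition and higher numbers for more inhibition at the one concentration tested (going by the name of the read-out)), compound 1 `O=C(NC1CCCC1)c1cc2ccccc2oc1=O` gives 18%. Compound 2 `O=C(NCCCO)c1cc2ccccc2oc1=O` gives 19% in this assay; the change between these two, (3-hydroxypropyl in place of cyclopentyl on an amide-type nitrogen), gave a number 1 percentage points higher from compound 1 to compound 2 (within the scatter). Compound 3 `N=c1oc2ccc(Br)cc2cc1C(=O)NC1CCCC1` gives 28% in this assay; its value and those of compound 1 and compound 2 lie within the scatter of one another, and the difference between the core of compound 3 and the core of compound 1 is not broken down here. Compound 4 `N=c1oc2ccc(Br)cc2cc1C(=O)NCCCO` carries the same change on the core of compound 3, (3-hydroxypropyl in place of cyclopentyl on an amide-type nitrogen), at the same place; among the compounds here this change occurs twice. The earlier instance gave a number 1 percentage points higher from compound 1 to compound 2 (within the scatter). On that basis a step of similar size is expected, a number 1 percentage points higher from compound 3 to compound 4 (within the scatter). Compound 4 is accordingly estimated at 29% in this assay, with a likely range of 16% to 42%.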

Compound 4, a percentage reported as inhibition, at one concentration (the size of the read-out at that concentration, not a potency): 25%
Compound 4: the middle estimate sits 4 percentage points above what was measured, and the stated range covers the measured number.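

In this assay, 3-hydroxypropyl in place of cyclopentyl on an amide-type nitrogen gave a number 3 percentage points lower from compound 3 to compound 4 (within the scatter). Set beside the earlier instance, the two steps do not differ: the same change on two cores in this assay, a number 1 percentage points higher (within the scatter) from compound 1 to compound 2 and a number 3 percentage points lower (within the scatter) from compound 3 to compound 4, 4 percentage points apart, within the scatter of two such steps. Within the data shown here, the change therefore reads the same on the core of compound 1 and the core of compound 3, but both steps lie within the scatter, so this shows only that neither core gives a measurable step, not that a larger step would carry from one core to the other.

From the compounds shown here alone, whether an amine, a carboxylic acid or a longer chain on the same nitrogen gives a step beyond the scatter stays open. Also open, going by these compounds, is whether any such step would hold on both cores.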